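Lengthening an Alkyl Chain by One Carbon

The compounds below may be only part of what the source reports. "The series", "measured", "known", "first", "only" and "open" are said of these compounds alone.

Three measured compounds share one core and differ only in the group on one carbon of that core. Compound 1 `O=C(Nn1c(-c2ccccc2)nc2c(-c3ccc(Cl)cc3)n[nH]c2c1=O)c1ccccc1` carries a phenyl there and gives 20600 nM in a functional assay on HT-29 cells (Homo sapiens) for inhibition, read by MTT assay, with a stated time of 2 days; a lower number here means a stronger inhibitor of growth, a higher number a weaker inhibitor of growth. Compound 2 `COc1cccc(Cc2nc3c(-c4ccc(Cl)cc4)n[nH]c3c(=O)n2NC(=O)c2ccccc2)c1` carries a 3-methoxybenzyl and gives 22100 nM; the change is a 1.1-fold higher number from compound 1 to compound 2 (0.03 log units; within the scatter). Compound 3 `CCCCc1nc2c(-c3ccc(Cl)cc3)n[nH]c2c(=O)n1NC(=O)c1ccccc1` carries a butyl and gives 710 nM, the lowest of the three numbers, reached through a 29-fold lower number from compound 1 to compound 3 (1.46 log units; beyond the scatter) and a 31-fold lower number from compound 2 to compound 3 (1.49 log units; beyond the scatter). Compound 4 `CCCCCc1nc2c(-c3ccc(Cl)cc3)n[nH]c2c(=O)n1NC(=O)c1ccccc1` is derived from compound 3 by methyl in place of hydrogen on a saturated chain carbon, four bonds along the chain from an aromatic carbon. Within the data shown here, no measured step tests a change of this kind: the two large steps replace an aromatic group by the chain rather than lengthen it, so they give no direction here. The step of a 1.1-fold lower number from compound 3 to compound 4 (0.04 log units; within the scatter) is therefore expected to stay within the scatter. For compound 4 the estimate is 650 nM, in the range 250 nM to 1700 nM.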

Compound 4, concentration for 50% growth inhibition: 2260 nM
For compound 4 the middle estimate is 3.5-fold (0.54 log units) below the measured one; the whole stated range lies below it.
By their numbers in this assay, from the lowest: compound 3; then compound 4; then compounds 1 and 2 (each within the scatter of the next).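

In this assay, among these compounds, this carbon proved sensitive to chain length, which no earlier step had tested: methyl in place of hydrogen four bonds along the chain from an aromatic carbon gave a 3.2-fold higher number from compound 3 to compound 4 (0.50 log units; beyond the scatter) and so weakened growth inhibition. The pentyl chain still outperformed both aromatic-bearing groups, with a 9.1-fold lower number from compound 1 to compound 4 (0.96 log units; beyond the scatter) and a 9.8-fold lower number from compound 2 to compound 4 (0.99 log units; beyond the scatter) for the changes at that carbon. Nothing measured here accounts for these differences.

As far as these compounds go, whether a propyl chain would give a lower or higher number than butyl stays open, as does the outcome for a hexyl chain or a chain ending in an amine.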